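Chain Extension on a Cyano-Bearing Oximate Imidazolium Salt

A few compounds are considered here, and "the series" means these few. Any claim that something is new, unique, unknown or untested is made for them only; others in the source may bear on it.

Measured so far:
compound 1, `C[n+]1ccn(COCCC[Si](C)(C)C)c1/C=N/O`, 0.43
compound 2, `C[n+]1ccn(CCC#N)c1/C=N/O`, -3.3

Of the compounds shown here, two have been measured in a physicochemical assay for lipophilicity; on this read-out lower numbers stand for lower lipophilicity and higher numbers for higher lipophilicity. Compound 1, `C[n+]1ccn(COCCC[Si](C)(C)C)c1/C=N/O`, gives 0.43 in this assay. Compound 2, `C[n+]1ccn(CCC#N)c1/C=N/O`, gives -3.3, the lowest of the two numbers; the number for compound 1 is the higher one, and the gap between the two lies well beyond the usual scatter of repeated measurements. Going by the values given here, no pair of measured compounds differs in one place only, so no single-step comparison is available from the measured set.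

The step followed here leads from compound 2 to compound 3, `C[n+]1ccn(CCCCC#N)c1/C=N/O`, which has not yet been measured in this assay. The difference is 2-cyanoethyl in place of cyano on a saturated chain carbon, two bonds along the chain from an aromatic nitrogen. Only the chain on the imidazolium nitrogen changes; the oxime and the shared core are kept.

Among the compounds with values here, with no measured step to rest on, the expectation for compound 3 rests on compound 2 and its value -3.3 alone. The step from compound 2 to compound 3 is expected to be a number 1.00 log units higher from compound 2 to compound 3 (beyond the scatter), upward and beyond the scatter. Compound 3 is therefore estimated at -2.3, within a range from -3.1 to -1.5.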

Compound 3, distribution coefficient: -2.8
The estimate for compound 3 lay 0.50 log units above the measured number; the measured number falls inside the stated range.
By their numbers in this assay, from the lowest: compound 2; then compound 3; then compound 1.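

Going by these compounds alone, this is the first step that changes one place only, so the chain on a saturated chain carbon, two bonds along the chain from an aromatic nitrogen, can now be read on its own: in this assay, putting 2-cyanoethyl in place of cyano gives a number 0.50 log units higher from compound 2 to compound 3 (beyond the scatter) while the oxime and the shared core stay the same. The two groups match in everything counted except size, each with one triple bond, one hydrogen-bond acceptor, no hydrogen-bond donor, no ring and no net charge, and the entering group has 4 heavy atoms against 2, all of the difference being carbon. The step therefore ties a modest rise on this read-out to a longer nitrile-ending chain at this position, though nothing available here explains the size of that rise.

A single step cannot show whether the number keeps rising in even increments as the chain grows, so a longer chain ending in a nitrile would be needed to test this. Nor do the compounds shown say how the read-out would respond if an amine or a carboxylic acid took the place of the nitrile at the end of this chain.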